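This account rests on a few compounds, and the source may have more. Where it says the series, first, only, none or still open, it means among the compounds named here.

Working notes on the series. In a functional assay, read by spectrophotometry, with a stated time of 20 min (a higher number here means a weaker inhibitor, a lower number a stronger inhibitor), compound 1 `Cc1ccc(-c2oc3ccccc3c(=O)c2C)cc1` gives 102 ug/mL and compound 2 `COc1ccc2c(=O)c(C)c(-c3ccc(Cl)cc3)oc2c1` gives 80.6 ug/mL. Going by the values given here, these two values lie within the usual scatter of each other, so compound 1 stands level with the only other measured compound.

Compound 3 `Cc1c(-c2ccc(Br)cc2)oc2ccccc2c1=O` has not yet been measured in this assay. It departs from compound 1 by a single change: bromo in place of methyl on an aromatic carbon, para to a large group. Among the compounds with values here, no two measured compounds differ in one place only, so the data hold no direct precedent for this replacement. Within the data shown here, the only indirect guide is compound 2, which also bears a halogen and gives 80.6 ug/mL.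

No direction is favoured, and nothing beyond the scatter is expected in this assay. The expected change is a 1.1-fold lower number from compound 1 to compound 3 (0.05 log units; within the scatter). For compound 3 the estimated value is 90 ug/mL, with an expected range of 45 ug/mL to 180 ug/mL.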

Compound 3, half-maximal inhibitory concentration: 111 ug/mL
Beside the measured number, compound 3's estimate is 1.2-fold (0.09 log units) below it; the range from low to high includes it.
By their numbers in this assay, from the lowest: compounds 2, 1 and 3 (each within the scatter of the next).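

In this assay, going by these compounds alone, the single change of bromo in place of methyl on an aromatic carbon, para to a large group, gives a 1.1-fold higher number from compound 1 to compound 3 (0.04 log units; within the scatter) and is the only direct reading of one replacement. At this position the assay therefore does not separate the two groups, which compound 2 could not show, as it differs from compound 1 in more than one place. No measured property bears on this result, so the data offer no account of the two groups reading alike.

Methyl and bromo both count no hydrogen-bond donors, no hydrogen-bond acceptors and no net charge, so the reading does not extend to an amine, a hydroxyl or a carboxylic acid on this carbon. As far as these compounds go, whether a longer chain or any such group here would move the number beyond the scatter remains open.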